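This account rests on a few compounds, and the source may have more. Where it says the series, first, only, none or still open, it means among the compounds named here.

Working notes on the dihydrofolate reductase series.

Of the compounds shown here, three have numbers so far. Compound 1 `CC1(C)N=C(N)N=C(N)N1c1cccc(CNC(=O)Nc2cccc(Cl)c2)c1` gives 8.05 in an assay on isolated protein for inhibition of Dihydrofolate reductase (Mus musculus); a higher number here means a more potent compound, by a factor of ten per unit of this negative logarithm, a lower number a less potent compound. Compound 2 `CC1(C)N=C(N)N=C(N)N1c1ccc(OCc2cccc(S(=O)(=O)F)c2Cl)c(Cl)c1` gives 7.49 in this assay, and compound 3 `CC1(C)N=C(N)N=C(N)N1c1ccc(CCc2ccc(S(=O)(=O)F)cc2Cl)c(Cl)c1` gives 8.33. Compound 1 thus stands second of the three: its number and that of compound 3 lie within the usual scatter of each other, so no order between them can be read, while compound 2 sits beyond the scatter below compound 1. No pair among these three differs in a single place, so nothing more than the bare values can be drawn from them.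

The next compound, compound 4 `COc1cccc(NC(=O)NCc2cccc(N3C(N)=NC(N)=NC3(C)C)c2)c1`, has not yet been measured in this assay. It differs from compound 1 in one place: methoxy in place of chloro on an aromatic carbon. The change sits on the (3-chlorophenyl)amino end of the urea, which becomes (3-methoxyphenyl)amino.

Within the data shown here, no measured step of this kind exists, so the expectation rests on compound 1 alone, whose value of 8.05 is the anchor. A small step, if any, is expected from compound 1 to compound 4, a number 0.25 log units lower from compound 1 to compound 4 (within the scatter), leaning slightly downward but not clearly beyond the scatter. Compound 4 is therefore estimated at 7.8, with a plausible range from 7.3 to 8.3.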

Compound 4, logarithm of the reciprocal of the active concentration, log(1/C): 8.02
Compound 4: the middle estimate sits 0.22 log units below what was measured; the range from low to high includes it.
By their numbers in this assay, from the lowest: compound 2; then compounds 4, 1 and 3 (each within the scatter of the next, the first and the last beyond it).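

In this assay, the series now has its first step that differs in one place, and methoxy in place of chloro on this aromatic carbon gives a number 0.03 log units lower from compound 1 to compound 4 (within the scatter). On the evidence of this single pair, the (3-chlorophenyl)amino and (3-methoxyphenyl)amino ends of the urea cannot be told apart in this assay, even though the exchange adds a heavy atom and a hydrogen-bond acceptor by the count of the two groups. So this position accepts at least one change of group with no readable shift in the number, though no measurement here bears on why the two groups read alike.

Going by these compounds, both groups are small, and neither carries a charge or a hydrogen-bond donor, so it remains open whether an amine, a carboxylic acid or a longer chain such as butoxy on the same carbon would stay as close to compound 1. On these data alone, it is also open whether methoxy in place of chloro would read the same on the chlorinated rings of compound 2 and compound 3, whose surroundings differ from those of the urea series.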